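The source may hold more compounds than are shown below. What is called first, only, known or untested is meant among the compounds shown, and "the series" means these compounds.

Among the compounds with values here, in a functional assay on Jurkat cells (Homo sapiens) (a higher number here means a weaker inhibitor, a lower number a stronger inhibitor), compound 3 `C[C@H](NC(=O)C(=O)NCc1cccc(Cl)c1Cl)C(=O)N[C@@H](CC(=O)O)C(=O)COc1c(F)c(F)cc(F)c1F` gives 76 nM, the lowest number so far, and compound 1 `C[C@H](NC(=O)C(=O)NCc1ccc(F)cc1)C(=O)N[C@@H](CC(=O)O)C(=O)COc1c(F)c(F)cc(F)c1F` gives 197 nM. Compound 2 `Cc1ccc(CNC(=O)C(=O)N[C@@H](C)C(=O)N[C@@H](CC(=O)O)C(=O)COc2c(F)c(F)cc(F)c2F)cc1C` reads > 10000 nM, which is a limit of the assay and not a number. Compound 4 `C[C@H](NC(=O)C(=O)NCc1cc(F)cc(F)c1)C(=O)N[C@@H](CC(=O)O)C(=O)COc1c(F)c(F)cc(F)c1F` is unmeasured and puts 3,5-difluorophenyl in place of 2,3-dichlorophenyl on a saturated chain carbon bound to an amide-type nitrogen. Measured swaps at this same place range widely. One is a 2.6-fold lower number from compound 1 to compound 3 (0.41 log units; beyond the scatter), which is modest, and another is an at least 50-fold higher number from compound 1 to compound 2 (1.70 log units; beyond the scatter), which is large. Fluorine-bearing compound 1, at 197 nM, is the closest measured match, so a modest rise is expected, with real uncertainty. The expected change is a 2.6-fold higher number from compound 3 to compound 4 (0.42 log units; beyond the scatter). The estimate for compound 4 is 200 nM, within a range of 60 nM to 1000 nM.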

Compound 4, half-maximal inhibitory concentration: 16 nM
Compound 4: middle estimate off by 13-fold (1.10 log units), on the high side; the whole stated range lies above it.
By their numbers in this assay, from the lowest: compound 4; then compound 3; then compound 1. At a limit, above all of these: compound 2.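

In this assay, the 3,5-difluorophenyl group gives a stronger inhibitor than either earlier measurable ring, with a 4.8-fold lower number from compound 3 to compound 4 (0.68 log units; beyond the scatter) and a 12-fold lower number from compound 1 to compound 4 (1.09 log units; beyond the scatter). Within the data shown here, the remaining step is open-ended, an at least 620-fold lower number from compound 2 to compound 4 (2.79 log units; beyond the scatter), as it rests on a limit and not a number: the limit of > 10000 nM in this assay, at which 1 of the 4 values shown sits. So this position can go lower than the earlier compounds showed, and swapping a dichlorophenyl for a difluorophenyl with the same heavy-atom count still moves the number.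

The compounds shown do not separate the halogen from its placement on the ring, which a 3,5-dichlorophenyl or 2,3-difluorophenyl group would address. Going by these compounds, whether a pyridine ring would serve here also remains open.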